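The compounds below may be only part of what the source reports. "The series", "measured", "known", "first", "only" and "open" are said of these compounds alone.

Of the compounds shown here, three sharing one core have been tested in a toxicity assay on L02 cells (Homo sapiens) for inhibition, read by MTT assay, with a stated time of 48 h; on this read-out lower numbers stand for stronger inhibition and higher numbers for weaker inhibition. Compound 1, `O=C(CC1CCOCC1)Nc1ccc(N2CCN(c3ccc(OC[C@@H]4CO[C@@](Cn5cncn5)(c5ccc(Cl)cc5Cl)O4)cc3)CC2)cc1`, carries an (oxan-4-yl)methyl group on the amide carbonyl carbon. In this assay compound 1 gives > 50000 nM, which is a limit of the assay rather than a measured number. Compound 2, `O=C(Nc1ccc(N2CCN(c3ccc(OC[C@@H]4CO[C@@](Cn5cncn5)(c5ccc(Cl)cc5Cl)O4)cc3)CC2)cc1)C(/C=C/Cl)C/C=C/C(F)(F)F`, has a 1-(2-chloroethenyl)-5,5,5-trifluoropent-3-en-1-yl group in that position. Compound 2 gives > 50000 nM, again only a limit. Compound 3, `O=C(Nc1ccc(N2CCN(c3ccc(OC[C@@H]4CO[C@@](Cn5cncn5)(c5ccc(Cl)cc5Cl)O4)cc3)CC2)cc1)c1ccco1`, bears a furan-2-yl group on the carbonyl carbon. Compound 3 gives > 50000 nM, also a limit. Compound 3 thus stands at the same limit as the other two, and nothing more exact is known about it. The steps a step that the two limits leave unreadable from compound 1 to compound 2, a step that the two limits leave unreadable from compound 1 to compound 3 and a step that the two limits leave unreadable from compound 2 to compound 3 cannot be read for that reason; the limit of > 50000 nM in this assay, at which 3 of the 3 values shown sit, describes where every value sits.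

Compound 4, `Cc1ccc(C(=O)Nc2ccc(N3CCN(c4ccc(OC[C@@H]5CO[C@@](Cn6cncn6)(c6ccc(Cl)cc6Cl)O5)cc4)CC3)cc2)o1`, differs from compound 3 by methyl in place of hydrogen on an aromatic carbon. For the measured compounds named here, none of the measured steps can be read, so no direction can be taken from them; they only show that changing the group on the carbonyl carbon left each compound at the limit. Compound 4 is expected to behave the same way, with a step that the limit leaves unreadable from compound 3 to compound 4 as the estimated step, most likely not measurable. Compound 4 is estimated at 80000 nM, within a range of 30000 nM to 300000 nM.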

Compound 4, half-maximal inhibitory concentration: > 50000 nM
Compound 4: no number, only a limit (the forecaster's own chance of this, stated with the estimate: 85%); the middle value lies beyond the limit too.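

In this assay compound 4 gives > 50000 nM, which is a limit and not a number. The steps to compound 4 from compound 1, compound 2 and compound 3 therefore cannot be read, because all four compounds share one limit: the limit of > 50000 nM in this assay, at which 4 of the 4 values shown sit.

The compounds shown leave open how far each one lies beyond that limit, so they cannot be ranked against one another.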